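Isopropyl in Place of Methyl: Expecting Compound 3

The source may report more compounds than this note shows. Statements on the series, on what has been measured and on what is new or still open speak of the compounds shown alone.

Of the compounds shown here, two have been measured in a functional assay for inhibition, with Oryctolagus cuniculus as the target; on this read-out higher numbers stand for weaker inhibition and lower numbers for stronger inhibition. Compound 1 `CC1=NC(C)=C(C(=O)OCCCN2C(=O)c3ccccc3S2(=O)=O)C(c2cccc([N+](=O)[O-])c2)/C1=C(\O)OC(C)C` gives 210 nM, and compound 2 `CO/C(O)=C1\C(C)=NC(C)=C(C(=O)OCCCN2C(=O)c3ccccc3S2(=O)=O)C1c1ccccc1Cl` gives 140 nM, the lower of the two numbers, though the gap to compound 1 lies within the usual scatter. Compound 3 `CC1=NC(C)=C(C(=O)OCCCN2C(=O)c3ccccc3S2(=O)=O)C(c2ccccc2Cl)/C1=C(\O)OC(C)C` is not yet measured; it differs from compound 2 by isopropyl in place of methyl on an oxygen on an unsaturated carbon. Going by the values given here, no measured pair shows this change alone, so only a small step is expected, in no clear direction, estimated as a 1.1-fold higher number from compound 2 to compound 3 (0.03 log units; within the scatter). Compound 3 is expected to give 150 nM, between 50 nM and 450 nM.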

Compound 3, half-maximal inhibitory concentration: 48 nM
Estimate against measurement, compound 3: 3.1-fold (0.49 log units) above, and the stated range ends above it.
By their numbers in this assay, from the lowest: compound 3; then compounds 2 and 1 (each within the scatter of the next).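

In this assay, the oxygen substituent at this place on the shared core matters: isopropyl in place of methyl brings a 2.9-fold lower number from compound 2 to compound 3 (0.46 log units; beyond the scatter) and thus a change larger than the earlier pair could show. With isopropoxy held constant, 2-chlorophenyl in place of 3-nitrophenyl brings a 4.4-fold lower number from compound 1 to compound 3 (0.64 log units; beyond the scatter) as a second step, so the saturated ring carbon's substituent counts as well. Nothing available explains either step. Still open, as far as these compounds go, is whether ethoxy or a longer chain on that oxygen would lower the number further, and whether isopropoxy gives a similar step alongside 3-nitrophenyl.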